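Trading 4-methoxyphenyl for 2-methylphenyl on compound 2

A few compounds are considered here, and "the series" means these few. Any claim that something is new, unique, unknown or untested is made for them only; others in the source may bear on it.

Three compounds have so far been measured in an assay on CHO cells for displacement of a labelled ligand from adenosine receptor A1 (Homo sapiens), tested at 10 uM; a higher number here means more inhibition at the concentration tested (going by the name of the read-out), a lower number less inhibition:
- compound 1, `COc1ccc(C(=O)Nc2nn(-c3ccccc3)c(=O)c3ccccc23)cc1`, gives 0%
- compound 2, `COc1ccc(NC(=O)Nc2nn(-c3ccccc3)c(=O)c3ccccc23)cc1`, gives 4%
- compound 3, `CC(=O)N(C(C)=O)c1nn(-c2ccccc2)c(=O)c2ccccc12`, gives 47%

Compound 2 holds the second highest of the three numbers. Among the compounds with values here, its nearest neighbour is compound 1, and the only step computed so far, a number 4 percentage points higher from compound 1 to compound 2 (within the scatter), lies within the scatter. Within the data shown here, compound 3 sits far above compound 2, beyond the scatter, but its structure differs in more than one place, so no step is computed for that pair.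

The new compound, compound 4, `Cc1ccccc1NC(=O)Nc1nn(-c2ccccc2)c(=O)c2ccccc12`, arises from compound 2 by a single change: 2-methylphenyl in place of 4-methoxyphenyl on an amide-type nitrogen. Among the measured compounds shown here, no measured step touches the group on the amide-type nitrogen, so the direction of this change is without precedent here. For the measured compounds named here, the one step that does exist, from compound 1 to compound 2, shows that a sizeable change on the carbonyl side left the read-out essentially unmoved. Without evidence of a change, the expectation is for a step of no size beyond the scatter, a number 4 percentage points higher from compound 2 to compound 4 (within the scatter). Compound 4 is therefore estimated at 8% in this assay, within a range from 0% to 25%.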

Compound 4, a percentage reported as inhibition, at one concentration (the size of the read-out at that concentration, not a potency): 20%
The estimate for compound 4 lay 12 percentage points below the measured number; the measured number falls inside the stated range.
By their numbers in this assay, from the lowest: compounds 1 and 2 (each within the scatter of the next); then compound 4; then compound 3.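

In this assay, the group on the amide-type nitrogen proves able to shift the read-out: the change to 2-methylphenyl gives a number 16 percentage points higher from compound 2 to compound 4 (beyond the scatter), whereas the earlier change on the carbonyl carbon, to (4-methoxyphenyl)amino, gave only a number 4 percentage points higher from compound 1 to compound 2 (within the scatter). Set against the 4-methoxyphenyl group on the carbonyl carbon, (2-methylphenyl)amino also gives a step that stands clear of the scatter, a number 20 percentage points higher from compound 1 to compound 4 (beyond the scatter), so the choice of aryl group on this urea-like link can separate compounds that otherwise share the same core. No measurement at hand says what lies behind this shift.

The change from 4-methoxyphenyl to 2-methylphenyl alters both the kind of group on the ring and where it sits, and the two cannot be told apart here: 4-methylphenyl and 2-methoxyphenyl would separate them, and plain phenyl would give a reference with neither group. On these data alone, it also remains open whether a group of another kind on the amide-type nitrogen, such as a benzyl group or a longer alkyl chain, would carry the read-out further in this assay.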